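This account rests on a few compounds, and the source may have more. Where it says the series, first, only, none or still open, it means among the compounds named here.

Measured so far in a functional assay on MGC-803 cells (Homo sapiens) for antiproliferative activity, read by CCK-8 assay, with a stated time of 72 h, tested at 2 uM; a lower number here means a weaker effect, a higher number a stronger effect of the compound at the concentration tested:
- compound 1, `Nc1ccccc1NC(=O)c1ccc(CSC(=S)N2CCN(c3ccccc3)CC2)cc1`, gives 42.3%
- compound 2, `CN1CCN(C(=S)SCc2ccc(C(=O)Nc3ccccc3N)cc2)CC1`, gives 29.6%

Compound 2 stands lowest of the two numbers; its nearest neighbour is compound 1, whose value lies above it by a step judged beyond the usual scatter. Among the compounds with values here, the two compounds share one core and differ only in what sits on the amine nitrogen in the ring: compound 1 carries a phenyl there, compound 2 a methyl, and the step of a number 12.7 percentage points lower from compound 1 to compound 2 (beyond the scatter) is the only comparison available.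

Compound 3, `Nc1ccccc1NC(=O)c1ccc(CSC(=S)N2CCN(Cc3cccnc3)CC2)cc1`, has not been measured. It is reached from compound 2 by the change (pyridin-3-yl in place of hydrogen on a saturated chain carbon bound to an amine nitrogen in a ring). Cut one bond further out, the methyl of compound 2 becomes (pyridin-3-yl)methyl, so an aromatic ring returns close to the ring nitrogen, though not in the same place as the phenyl of compound 1 and with a nitrogen in it.

The measured step from compound 1 to compound 2 bears on this: removing the phenyl cost a modest amount. Bringing an aromatic ring back is therefore expected to raise the value in this assay by a comparable, modest amount, with real uncertainty about whether this ring counts like the phenyl did. Compound 3 is estimated at 38%, within 26% to 50%, an expected step of a number 8.4 percentage points higher from compound 2 to compound 3 (within the scatter).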

Compound 3, a percentage reported as inhibition, at one concentration (the size of the read-out at that concentration, not a potency): 37.7%
Compound 3: the middle estimate sits 0.3 percentage points above what was measured; low and high end bracket the measured number.
By their numbers in this assay, from the lowest: compounds 2, 3 and 1 (each within the scatter of the next, the first and the last beyond it).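

In this assay, an amine nitrogen in a ring can carry a (pyridin-3-yl)methyl group while the read-out stays within the span set by the two earlier compounds: the change from methyl gives a number 8.1 percentage points higher from compound 2 to compound 3 (within the scatter), and the change from phenyl gives a number 4.6 percentage points lower from compound 1 to compound 3 (within the scatter). Compound 3 therefore cannot be told apart from either compound 1 or compound 2, even though those two differ by a step beyond the scatter, so this one change does not settle whether an aromatic ring at this place matters for the read-out. No measurement on hand accounts for these numbers.

The compounds shown leave open whether a benzyl group on the same nitrogen, which keeps the saturated chain carbon but has no nitrogen in its ring, would read like compound 3 or compound 1, and whether pyridin-2-yl or pyridin-4-yl in place of pyridin-3-yl would change the result. As far as these compounds go, with only one tested concentration, the read-out gives the size of an effect at that concentration rather than a potency, so how these compounds rank across a range of concentrations also remains open.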